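Chlorine for dimethyl on the aryl of the shared core

This account rests on a few compounds, and the source may have more. Where it says the series, first, only, none or still open, it means among the compounds named here.

In a functional assay on the whole organism for inhibition, with Mythimna separata as the target, with a stated time of 5 days (on this read-out higher numbers stand for an effect only at larger amounts of compound and lower numbers for an effect already at smaller amounts), compound 1 `CC(C)(C)n1ncc(OCc2nnc(-c3ccc(Br)cc3)o2)c(Cl)c1=O` gives 21400 nM. For compound 2 `Cc1cc(C)cc(-c2nnc(COc3cnn(C(C)(C)C)c(=O)c3Cl)o2)c1` this assay reports only a limit, > 299000 nM, and no number; this is the limit of > 299000 nM in this assay, at which 1 of the 2 values shown sits. Going by the values given here, the single measured step, an at least 13-fold higher number from compound 1 to compound 2 (1.14 log units; beyond the scatter), shows the 4-bromophenyl standing far better than the 3,5-dimethylphenyl. Compound 3 `CC(C)(C)n1ncc(OCc2nnc(-c3ccc(Cl)cc3)o2)c(Cl)c1=O` carries 4-chlorophenyl in place of 3,5-dimethylphenyl on an aromatic carbon, a group close in kind to the 4-bromophenyl of compound 1. A reversal of roughly that size is expected, so compound 3 is expected to fall back sharply: an at least 9.9-fold lower number from compound 2 to compound 3 (0.99 log units; beyond the scatter). Compound 3 is estimated at 30000 nM, with a range from 8000 nM to 150000 nM.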

Compound 3, half-maximal effective concentration: 1900 nM
For compound 3 the middle estimate is 16-fold (1.20 log units) above the measured one, and the stated range ends above it.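

In this assay, the two halogens are not interchangeable on this aryl: chloro in place of bromo brings an 11-fold lower number from compound 1 to compound 3 (1.05 log units; beyond the scatter). The 4-chlorophenyl also stands far ahead of the 3,5-dimethylphenyl, with an at least 150-fold lower number from compound 2 to compound 3 (2.19 log units; beyond the scatter). The reading for compound 2 in that step is a limit and not a number: the limit of > 299000 nM in this assay, at which 1 of the 3 values shown sits.

The compounds shown leave open whether a 4-fluorophenyl or a 4-trifluoromethylphenyl would continue the gain seen with chloro. They also leave open whether a 4-methylphenyl would hold up, or whether a 4-aminophenyl would be tolerated on the shared core.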